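The compounds below may be only part of what the source reports. "The series", "measured", "known", "first", "only" and "open" are said of these compounds alone.

Working notes on the series

Three compounds have numbers in hand. Compound 1 `CCC[C@@H](OC(C)=O)C1=C(Br)/C(=C/Br)OC1=O` gives 1.7 ug/mL in a functional assay on Lu1 cells (Homo sapiens) for cytotoxicity; a higher number here means that more compound is needed for the effect, a lower number that less compound is needed. Compound 2 `CCC[C@@H](OC(C)=O)C1=C(Br)[C@@](CI)(OC)OC1=O` reaches only the limit of the assay in this assay, at > 20 ug/mL; this is a limit, not a number. Compound 3 `CCC[C@@H](O)C1=C(Br)/C(=C\Br)OC1=O` gives 0.6 ug/mL in this assay. On the two real numbers compound 3 stands lowest, and compound 1 sits a step beyond the scatter higher than compound 3. Among the compounds with values here, the one limit value, that of compound 2, stands at the cut-off described under (the limit of > 20 ug/mL in this assay, at which 1 of the 3 values shown sits).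

The step under study goes from compound 3 to compound 4 `CCC[C@@H](O)C1=C(Br)/C(=C/Br)OC1=O`. The change is the two compounds have the same atoms and bonds and differ only in configuration as drawn: 1 of 2 stereo elements differ; a double bond is drawn E in compound 3 and Z in compound 4. Within the data shown here, no measured pair in the set shares this change, so its size is unknown here. Since only the drawn configuration of the double bond moves, and the hydroxyl and the brominated core stay as in compound 3 at 0.6 ug/mL, the expectation is a step near or within the scatter, with no firm direction. The estimate for compound 4 in this assay is 1 ug/mL, from 0.4 ug/mL to 3 ug/mL, which is expected to mean a step of a 1.7-fold higher number from compound 3 to compound 4 (0.22 log units; within the scatter).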

Compound 4, concentration for half-maximal effect: 0.3 ug/mL
Compound 4: the middle estimate sits 3.3-fold (0.52 log units) above what was measured, and the stated range ends above it.
By their numbers in this assay, from the lowest: compounds 4 and 3 (each within the scatter of the next); then compound 1. At a limit, above all of these: compound 2.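

In this assay, within the data shown here, the two drawn forms of the double bond are not told apart on the hydroxyl series, with a 2.0-fold lower number from compound 3 to compound 4 (0.30 log units; within the scatter), and this is the first reading of that change on its own, free of any other difference: the fact that compounds 3 and 4 differ only in the configuration as drawn. Among these compounds, compound 1 and compound 4 carry the double bond drawn the same way, so they give the first one-place reading at the oxygen, where hydrogen in place of acetyl on an oxygen on a saturated carbon gives a 5.7-fold lower number from compound 1 to compound 4 (0.75 log units; beyond the scatter). Among the compounds shown here, of the two steps, only the one at the oxygen lies beyond the scatter, and it rests on this single pair.

The compounds shown leave open whether that step from acetyl to hydrogen holds with the double bond drawn E, and so whether the two changes act independently of each other. They also leave open how the oxygen behaves with anything other than hydrogen or acetyl, such as a methyl ether or a benzoate ester, and how the series responds to a longer chain on the carbon that carries this oxygen.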